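The source may hold more compounds than are shown below. What is called first, only, known or untested is meant among the compounds shown, and "the series" means these compounds.

Measured compounds:
Compound 1 `Nc1ccccc1NC(=O)/C=C/c1ccc(CSc2ccc(F)cc2)cc1` gives 10.4% in a functional assay on HeLa cells (Homo sapiens) for inhibition, read by CCK-8 assay, with a stated time of 72 h, tested at 8 uM; on this read-out lower numbers stand for less inhibition of growth and higher numbers for more inhibition of growth at the one concentration tested.
Compound 2 `COc1ccc(SCc2ccc(C(=O)Nc3ccccc3N)cc2)cc1` gives 79.7% in this assay.
Compound 3 `Nc1ccccc1NC(=O)/C=C/c1ccc(CSc2cccc3ccccc23)cc1` gives 22.1% in this assay.

Among these three, compound 2 stands highest, with compound 3 the nearest and compound 1 the furthest away, both gaps being well beyond the scatter of the assay. Compound 4 `Nc1ccccc1NC(=O)c1ccc(CSc2ccc(Cl)cc2)cc1` has not yet been measured. It differs from compound 2 in one place: chloro in place of methoxy on an aromatic carbon. For the measured compounds named here, the only measured step that changes a group on the sulfur is the one from compound 1 to compound 3, where a naphthalen-1-yl replaced a 4-fluorophenyl and gave a number 11.7 percentage points higher from compound 1 to compound 3 (beyond the scatter). That step sits on a different linker and swaps a different group, so it bears only loosely on the change here. Compound 4 carries a chloro in the same place as the fluoro of compound 1, which gives 10.4%, but the linker of compound 1 also differs from that of compound 2, so its low number cannot be laid at the door of the halogen alone. Going by the values given here, with no direct precedent for chloro in place of methoxy, a moderate drop from the high number of compound 2 is expected, with wide uncertainty. Compound 4 is therefore estimated at 60%, within 30% to 85%, which means an expected step of a number 19.7 percentage points lower from compound 2 to compound 4 (beyond the scatter).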

Compound 4, percent growth inhibition at one concentration: 51.4%
Beside the measured number, compound 4's estimate is 8.6 percentage points above it; the range from low to high includes it.
By their numbers in this assay, from the lowest: compound 1; then compound 3; then compound 4; then compound 2.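

In this assay, for the compounds shown here, changing 4-methoxyphenyl to 4-chlorophenyl gives a number 28.3 percentage points lower from compound 2 to compound 4 (beyond the scatter), the first measured step that changes only this group on the core of compound 2. The position is therefore not indifferent to what sits there: a swap on an aromatic carbon, para to a large group, moves the read-out by more than the usual scatter. The change lowers growth inhibition without abolishing it, since compound 4 still gives 51.4% at the one concentration tested. No measurement here accounts for the size or direction of this step.

As far as these compounds go, with only methoxy and chloro compared on this core, two substituents cannot establish a trend, so it remains open where an amine, a carboxylic acid, a methyl group or a plain hydrogen would fall at this position. From the compounds shown here alone, it is also open whether the same swap would give a step of similar size on the linker of compound 1, and whether the gap would hold at other concentrations in this assay.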